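Hydroxy in Place of Methoxy: Expecting Compound 4

The source may report more compounds than this note shows. Statements on the series, on what has been measured and on what is new or still open speak of the compounds shown alone.

Three compounds sharing one core were tested in a functional assay on A549 cells (Homo sapiens) for cytotoxicity, read by sulforhodamine B assay, with a stated time of 48 h, tested at 10 uM; on this read-out higher numbers stand for a weaker effect at the one concentration tested and lower numbers for a stronger effect. Compound 1 `COc1cc(C)cc(-c2c(-c3ccnc(-c4ccc(C(C)=O)cc4)c3)cnn2CC#N)c1` gives 30%. Compound 2 `Cc1cc(O)cc(-c2nn(CC#N)cc2-c2ccnc(-c3ccc(Oc4ccccc4)cc3)c2)c1` gives -71%, and compound 3 `COc1cc(C)cc(-c2nn(CC#N)cc2-c2ccnc(-c3ccc(N(C)C)cc3)c2)c1` gives -6%. Among these three numbers compound 3 stands second highest: compound 1 lies higher by a gap beyond the scatter, compound 2 lower by a wider gap, also beyond the scatter. Compound 4 `Cc1cc(O)cc(-c2nn(CC#N)cc2-c2ccnc(-c3ccc(N(C)C)cc3)c2)c1` is not yet measured. It differs from compound 3 in one place: hydrogen in place of methyl on an oxygen on an aromatic ring. Going by the values given here, no measured pair shows this exact change, so its size is uncertain. Compound 2, which also carries the hydroxy on that ring, gives -71%, hinting at a lower number. For compound 4 a step of a number 24 percentage points lower from compound 3 to compound 4 (beyond the scatter) toward a stronger effect is expected. Compound 4 is estimated at -30%, within -70% to 15%.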

Compound 4, a percentage reported as activity, at one concentration (the size of the read-out at that concentration, not a potency): -8%
Compound 4: middle estimate off by 22 percentage points, on the low side; the range from low to high includes it.
By their numbers in this assay, from the lowest: compound 2; then compounds 4 and 3 (each within the scatter of the next); then compound 1.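

In this assay, replacing methoxy with hydroxy on the aromatic ring gives a number 2 percentage points lower from compound 3 to compound 4 (within the scatter), so with dimethylamino on the other end of the molecule, these two groups cannot be told apart at this position. The second comparison gives a number 63 percentage points higher from compound 2 to compound 4 (beyond the scatter), which ties the low number of compound 2 to its phenoxy group rather than to the hydroxy they share. Nothing shown gives a reason for either step. Still open, as far as these compounds go, is whether a longer chain on that oxygen, such as ethoxy, or an amine in its place would match these results.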